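The source may hold more compounds than are shown below. What is called first, only, known or untested is meant among the compounds shown, and "the series" means these compounds.

Of the compounds shown here, three sharing one core have been measured in a functional assay (Oryctolagus cuniculus) for inhibition of platelet-activating factor receptor (Cavia porcellus); on this read-out higher numbers stand for weaker inhibition and lower numbers for stronger inhibition. Compound 1 `CCCC(=O)OCC1CN(C(=O)c2cc(OC)c(OC)c(OC)c2)CCN1C(=O)c1cc(OC)c(OC)c(OC)c1` gives 420 nM. Compound 2 `COc1cc(C(=O)N2CCN(C(=O)c3cc(OC)c(OC)c(OC)c3)C(COC(=O)NC(C)C(C)(C)C)C2)cc(OC)c1OC` gives 170 nM, and compound 3 `COc1cc(C(=O)N2CCN(C(=O)c3cc(OC)c(OC)c(OC)c3)C(COC(=O)NC(C)C(C)C)C2)cc(OC)c1OC` gives 80 nM, the lowest of the three numbers, set apart from both others by more than the scatter. The recorded steps are a 2.5-fold lower number from compound 1 to compound 2 (0.39 log units; beyond the scatter), a 5.3-fold lower number from compound 1 to compound 3 (0.72 log units; beyond the scatter) and, among the two carbamates, a 2.1-fold lower number from compound 2 to compound 3 (0.33 log units; beyond the scatter).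

Compound 4 `COc1cc(C(=O)N2CCN(C(=O)c3cc(OC)c(OC)c(OC)c3)C(COC(=O)NCCC(C)C)C2)cc(OC)c1OC` has not yet been measured. It differs from compound 3 by isopentyl in place of 1,2-dimethylpropyl on an amide-type nitrogen. Within the data shown here, no measured step moves the branching along the chain in this way, so the only guide is the carbamate pair, where the step of a 2.1-fold lower number from compound 2 to compound 3 (0.33 log units; beyond the scatter) was modest. A step of similar or smaller size is therefore expected for compound 4, with the direction uncertain and a slight weakening thought a little more likely than a gain.

For compound 4 in this assay the estimate is 120 nM, ranging from 50 nM to 300 nM. The expected step is a 1.5-fold higher number from compound 3 to compound 4 (0.18 log units; within the scatter).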

Compound 4, half-maximal inhibitory concentration: 140 nM
Compound 4: middle estimate off by 1.2-fold (0.07 log units), on the low side; the range from low to high includes it.
By their numbers in this assay, from the lowest: compounds 3, 4 and 2 (each within the scatter of the next, the first and the last beyond it); then compound 1.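

In this assay, isopentyl in place of 1,2-dimethylpropyl on the amide-type nitrogen gives a 1.8-fold higher number from compound 3 to compound 4 (0.24 log units; within the scatter) and isopentyl in place of 1,2,2-trimethylpropyl gives a 1.2-fold lower number from compound 2 to compound 4 (0.08 log units; within the scatter) so compound 4 cannot be separated from either carbamate, even though compound 2 and compound 3 stand apart from each other. Against the ester, isopentylamino in place of propyl on a carbonyl carbon gives a 3.0-fold lower number from compound 1 to compound 4 (0.48 log units; beyond the scatter) and this shows that the gain seen with the two earlier carbamates holds with isopentyl as well. No measurement at hand bears on why the numbers fall this way.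

Going by these compounds, whether a longer chain, a cyclohexyl group or an amine on this nitrogen would keep the number in the same range remains open. So does how far a chain can be shortened there, for instance to ethyl, before the gain over compound 1 is lost.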